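A few compounds are considered here, and "the series" means these few. Any claim that something is new, unique, unknown or untested is made for them only; others in the source may bear on it.

Compound 1 `O=C(O)CCNC(=O)c1ccc(C(Oc2ccc(-n3cc(C(F)(F)F)cn3)cc2)C2CCCC2)cc1`: 22 mL/min/kg
Compound 2 `O=C(O)CCNC(=O)c1ccc(C(Oc2ccc(-n3cc(C(F)(F)F)cn3)cc2)C2CC2)cc1`: < 8 mL/min/kg
Compound 3 `CCCC(Oc1ccc(-n2cc(C#N)cn2)cc1)c1ccc(C(=O)NCCC(=O)O)cc1`: < 8 mL/min/kg

In an ADME assay on microsomes from liver (Homo sapiens) for metabolic stability (a higher number here means faster removal of the compound, a lower number slower removal), compound 1 gives 22 mL/min/kg. For compound 2 the assay reports only a limit, < 8 mL/min/kg. That gives an at least 2.7-fold lower number from compound 1 to compound 2 (0.43 log units; beyond the scatter). Compound 3 likewise stands at a limit, < 8 mL/min/kg, so its true value is not known, only (the limit of < 8 mL/min/kg in this assay, at which 2 of the 3 values shown sit).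

Compound 4 `CCCC(Oc1ccc(-n2cc3c(n2)CCCC3)cc1)c1ccc(C(=O)NCCC(=O)O)cc1` differs from compound 3 in one place: a group of 9 heavy atoms (7 carbon, 2 nitrogen; one five-membered aromatic ring with 2 hetero atoms, one six-membered non-aromatic ring of carbon only) in place of a group of 7 heavy atoms (4 carbon, 3 nitrogen; one five-membered aromatic ring with 2 hetero atoms), on an aromatic carbon. Among the measured compounds shown here, no measured step shares this change; the only step measured concerns a different group on a different carbon, so it does not bear on it. The estimate therefore rests on where compound 3 stands, and the expected step is an at least 1.2-fold higher number from compound 3 to compound 4 (0.09 log units; that floor lies within the scatter). Compound 4 is expected to give 10 mL/min/kg, in the range 4 mL/min/kg to 25 mL/min/kg.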

Compound 4, clearance: 48 mL/min/kg
Beside the measured number, compound 4's estimate is 4.8-fold (0.68 log units) below it, and the stated range ends below it.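

Among the compounds shown here, at this position, on an aromatic carbon para to a large group, the earlier compounds showed no change. In this assay, replacing 4-cyano-1H-pyrazol-1-yl with the group carrying a six-membered non-aromatic ring of carbon only gives an at least 6.0-fold higher number from compound 3 to compound 4 (0.77 log units; beyond the scatter), so this group, too, moves the clearance beyond the scatter. That step is only a floor, since compound 3 stands at a limit: the limit of < 8 mL/min/kg in this assay, at which 2 of the 4 values shown sit.

The compounds shown leave open whether the loss of the nitrile or the gain of the non-aromatic ring carries the step. A 4-methyl-1H-pyrazol-1-yl group, which has neither, could separate the two.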